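A few compounds are considered here, and "the series" means these few. Any claim that something is new, unique, unknown or untested is made for them only; others in the source may bear on it.

Of the compounds shown here, three have been measured in a functional assay on the whole organism with Mus musculus as the target; a lower number here means that less compound is needed, a higher number that more compound is needed for the effect. Compound 1 `CN1CCN(C(=O)/C=C/c2cccc(C(F)(F)F)c2)CC1` gives > 75 mg/kg, which is a limit of the assay and not a number. For the measured compounds named here, compound 2 `CN1C(=O)CCC1(O)c1cccc(C(F)(F)F)c1` gives 51.6 mg/kg, the only exact number among the three. Compound 3 `CN1C(=O)CCC1(O)c1cccc(Cl)c1` gives > 150 mg/kg, and this too is a limit and not a number, so compound 3 has no exact place on the scale.

Compound 4 `Cc1cccc(C2(O)CCC(=O)N2C)c1` keeps the shared core and carries methyl in place of chloro on an aromatic carbon. Going by the values given here, no measured step exchanges these two groups. The closest guide is an at least 2.9-fold higher number from compound 2 to compound 3 (0.46 log units; beyond the scatter), a step beyond the scatter that swaps a different pair of groups at the same place on the same core. It shows that this assay can respond to a change there, but it gives neither size nor direction for the new exchange. No step beyond the scatter is therefore expected, although the assay may again report only a limit. The estimate amounts to a number no higher from compound 3 to compound 4 (the limit leaves the size open), which is expected to stay within the scatter. For compound 4 the expected value is 150 mg/kg, with an estimated range from 70 mg/kg to 320 mg/kg.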

Compound 4, dose for half-maximal effect: 60.9 mg/kg
Compound 4: the middle estimate sits 2.5-fold (0.39 log units) above what was measured, and the stated range ends above it.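

In this assay methyl in place of chloro on an aromatic carbon gives an at least 2.4-fold lower number from compound 3 to compound 4 (0.39 log units; beyond the scatter) and thus moves the result beyond the scatter, which no earlier step had shown for this pair of groups. Methyl and trifluoromethyl at this place on the shared core are not told apart, with a 1.2-fold higher number from compound 2 to compound 4 (0.07 log units; within the scatter) as their step, so among the three groups compared here chloro alone stands apart from the other two. As far as these compounds go, how far chloro stands apart remains unknown, because the value of compound 3 is a limit and not a number: the limit of > 150 mg/kg in this assay, at which 1 of the 4 values shown sits.

Whether a methoxy group, an amine or a longer chain at this place would stay close to methyl and trifluoromethyl or fall with chloro is open, as is whether the same order of groups would hold on another aromatic carbon. Compound 1 gives > 75 mg/kg as a limit and not a number, and its core differs from the shared core, so it adds nothing on these exchanges.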